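Adding a pyrazolylamino group to a sub-nanomolar LRRK2 ligand

A few compounds are considered here, and "the series" means these few. Any claim that something is new, unique, unknown or untested is made for them only; others in the source may bear on it.

Compound 1 `Cn1c(N2CCCC2)c(C#N)c2c(N)ncnc21` gives 41 nM in an assay on isolated protein for binding affinity to Leucine-rich repeat serine/threonine-protein kinase 2 (Homo sapiens), read by TR-FRET and LanthaScreen, with a stated time of 2 h; a lower number here means a stronger inhibitor, a higher number a weaker inhibitor. Compound 2 `C[C@@H]1CCCN1c1c(C#N)c2c(N)ncnc2n1C` gives 0.4 nM.

Compound 2 holds the lowest of the two numbers; its nearest neighbour is compound 1, and the step of a 100-fold lower number from compound 1 to compound 2 (2.01 log units; beyond the scatter) separates them. Compound 3 `Cc1n[nH]cc1Nc1nc(N)c2c(C#N)c(N3CCC[C@H]3C)n(C)c2n1` differs from compound 2 by (3-methyl-1H-pyrazol-4-yl)amino in place of hydrogen on an aromatic carbon. Among the compounds with values here, no measured step touches that place, so the one step at hand, from compound 1 to compound 2, does not bear on it. Compound 3 is therefore expected to stay near compound 2, with a 1.3-fold lower number from compound 2 to compound 3 (0.12 log units; within the scatter) as the estimated change. The expected value for compound 3 is 0.3 nM, within 0.05 nM to 2 nM.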

Compound 3, inhibition constant: 1 nM
The estimate for compound 3 lay 3.3-fold (0.52 log units) below the measured number; measured number inside the range.
By their numbers in this assay, from the lowest: compound 2; then compound 3; then compound 1.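

In this assay, the aromatic carbon between two ring nitrogen atoms takes (3-methyl-1H-pyrazol-4-yl)amino with only a modest loss, a 2.5-fold higher number from compound 2 to compound 3 (0.40 log units; beyond the scatter). Even with this five-membered aromatic ring attached, compound 3 stays at 1 nM, so the position accepts a substituent far bigger than hydrogen. Nothing available explains the shift.

On these data alone, whether a smaller group on this carbon, such as a plain amino or a methoxy group, would behave the same remains open. So does the contribution of the methyl on the pyrazole.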